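Moving one methoxy group on compound 2

A few compounds are considered here, and "the series" means these few. Any claim that something is new, unique, unknown or untested is made for them only; others in the source may bear on it.

Compound 1 `COc1cccc(C(=O)Nc2nnc(/C=C/c3cc(OC)c(OC)c(OC)c3Br)s2)c1` gives 60 nM
Compound 2 `COc1ccc(/C=C/c2nnc(NC(=O)c3cc(OC)c(OC)c(OC)c3Br)s2)cc1` gives 180 nM

In a functional assay on A549 cells (Homo sapiens) for antiproliferative activity, read by MTT assay, with a stated time of 48 h (a lower number here means a stronger inhibitor, a higher number a weaker inhibitor), compound 2 has the higher number of the two and is the weaker inhibitor, with its gap to compound 1 lying beyond the usual scatter. Compound 3 `COc1cccc(/C=C/c2nnc(NC(=O)c3cc(OC)c(OC)c(OC)c3Br)s2)c1` is still unmeasured and differs from compound 2 by one swap 3-methoxyphenyl in place of 4-methoxyphenyl on a double-bonded chain carbon bound to a double-bonded chain carbon with the same atoms joined differently. Going by the values given here, no measured pair shows this swap, so only a small drop in this assay is expected, probably within the scatter, the estimated 1.4-fold lower number from compound 2 to compound 3 (0.14 log units; within the scatter) being a cautious guess. Compound 3 is estimated at 130 nM with an expected range of 45 nM to 380 nM in this test.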

Compound 3, half-maximal inhibitory concentration: 190 nM
For compound 3 the middle estimate is 1.5-fold (0.16 log units) below the measured one, and the stated range covers the measured number.
By their numbers in this assay, from the lowest: compound 1; then compounds 2 and 3 (each within the scatter of the next).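

In this assay, the swap gives a 1.1-fold higher number from compound 2 to compound 3 (0.02 log units; within the scatter) and stays within the scatter, so 3-methoxyphenyl and 4-methoxyphenyl cannot be told apart on this double-bonded chain carbon. Going by these compounds alone, this is the first direct reading of the swap, and for this pair, where the methoxy group sits on the ring makes no measurable difference. No available evidence explains this result.

On these data alone, whether the same holds for other groups on this ring stays open. An amine or a carboxylic acid in place of the methoxy group could give a quite different number.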